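The source may report more compounds than this note shows. Statements on the series, on what has been measured and on what is new or still open speak of the compounds shown alone.

Measured in a functional assay on Caov-3 cells (Homo sapiens) for antiproliferative activity, read by CellTiter-Glo, with a stated time of 96 h; a lower number here means a stronger inhibitor, a higher number a weaker inhibitor:
- Compound 1 `COc1ccc(-c2nsc3c2NC(=O)CC3c2ccc(F)cc2)cc1`: > 2000 nM (a limit of the assay)
- Compound 2 `COc1ccc(-c2nsc3c2NC(=O)CC3c2ccsc2)cc1`: 152 nM

Going by the values given here, compound 2, at 152 nM, holds the only exact number so far. The entry for compound 1 is only a limit. Compound 3 `O=C1CC(c2ccsc2)c2snc(-c3ccc(Cl)cc3)c2N1` has chloro in place of methoxy on an aromatic carbon. Among the compounds with values here, the single measured step, an at least 13-fold lower number from compound 1 to compound 2 (1.11 log units; beyond the scatter), is large, but it lies on a saturated ring carbon, not at this site, so it suggests no direction here. The estimated step is a 1.3-fold higher number from compound 2 to compound 3 (0.12 log units; within the scatter), which is not expected to exceed the scatter. For compound 3 the expected value is 200 nM, with an estimated range of 60 nM to 700 nM.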

Compound 3, half-maximal inhibitory concentration: 1080 nM
Beside the measured number, compound 3's estimate is 5.4-fold (0.73 log units) below it, outside the stated range (above it).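

Chloro in place of methoxy, on an aromatic carbon para to a large group, brings a 7.1-fold higher number from compound 2 to compound 3 (0.85 log units; beyond the scatter) in this assay. This site therefore also moves the number beyond the scatter, and here methoxy gives the stronger inhibitor of the two. Nothing shown explains why this change weakens the compound.

From the compounds shown here alone, with only these two groups at this site, it stays open whether the loss comes from removing methoxy or from adding chloro; a hydroxyl, fluoro or ethoxy group there would help separate the two. Going by these compounds, it also stays open whether the change has the same size with another group on the saturated ring carbon.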